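The source may report more compounds than this note shows. Statements on the series, on what has been measured and on what is new or still open speak of the compounds shown alone.

Measured so far:
- compound 1, `Cc1nc(S(C)(=O)=O)ccc1Oc1ncnc(OC2CCN(C(=O)SC3CCC3)CC2)c1F`, 77.4 nM in a functional assay on isolated protein for inhibition of Glucose-dependent insulinotropic receptor (Rattus norvegicus), read by HTRF and cAMP accumulation; on this read-out higher numbers stand for an effect only at larger amounts of compound and lower numbers for an effect already at smaller amounts
- compound 2, `Cc1nc(S(C)(=O)=O)ccc1Oc1ncnc(OC2CCN(C(=O)C(C)(C)F)CC2)c1F`, 296 nM in this assay

Compound 2 stands at the highest of the two numbers seen so far; its nearest neighbour is compound 1, and the step of a 3.8-fold higher number from compound 1 to compound 2 (0.58 log units; beyond the scatter) separates them. That step is the only one available, and it shows that swapping the group on the carbonyl carbon can move the result by a modest but real amount.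

Compound 3, `Cc1nc(S(C)(=O)=O)ccc1Oc1ncnc(OC2CCN(C(=O)c3ncc(Cl)cn3)CC2)c1F`, has not yet been measured. It differs from compound 2 in one place: 5-chloropyrimidin-2-yl in place of 1-fluoro-1-methylethyl on a carbonyl carbon. The step from compound 1 to compound 2 bears on this only loosely, since it exchanges one small non-aromatic group for another, while here an aromatic ring with two ring nitrogens takes the place of the small group. The direction of that earlier step gives no firm guide. The expected outcome for compound 3 is a return toward lower numbers, with an estimated step of a 2.5-fold lower number from compound 2 to compound 3 (0.39 log units; beyond the scatter) in this assay. The estimated value for compound 3 is 120 nM, within a range from 30 nM to 500 nM.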

Compound 3, half-maximal effective concentration: 30.9 nM
Beside the measured number, compound 3's estimate is 3.9-fold (0.59 log units) above it, within the range that was stated.
By their numbers in this assay, from the lowest: compound 3; then compound 1; then compound 2.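

Until now, only small non-aromatic groups had been seen on this carbonyl carbon, whose other neighbour is an amide-type nitrogen in a ring; compound 3 shows that an aromatic ring can sit there with the number falling rather than rising in this assay. Replacing 1-fluoro-1-methylethyl with 5-chloropyrimidin-2-yl gives a 9.6-fold lower number from compound 2 to compound 3 (0.98 log units; beyond the scatter), and replacing cyclobutylsulfanyl with the same ring gives a 2.5-fold lower number from compound 1 to compound 3 (0.40 log units; beyond the scatter), so compound 3 has the lowest number of the three, with both gaps beyond the usual scatter. Nothing available explains why this ring lowers the number, so the result stands as an observation only.

Because the new group brings in a ring, ring nitrogens and a chlorine all at once, the compounds shown cannot say which of these parts goes with the lower number. Plain phenyl, 4-chlorophenyl or pyrimidin-2-yl without the chlorine on the same carbonyl carbon would begin to separate these parts, and a bromine or a methyl group in the chlorine's place would show how much depends on that one atom.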